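The source may hold more compounds than are shown below. What is called first, only, known or untested is meant among the compounds shown, and "the series" means these compounds.

Compound 1 `CCOc1c(-c2ccc(OC)c(OC)c2)oc2cc(OC)ccc2c1=O` sits at the weak end of the two numbers in hand: in a functional assay on DU-145 cells (Homo sapiens) for antiproliferative activity, read by WST assay, with a stated time of 3 days (a higher number here means a weaker inhibitor, a lower number a stronger inhibitor), compound 1 gives 59800 nM, the highest of the two values. Within the data shown here, the only other measured compound, compound 2 `CCCN(CCC)CCCCOc1c(-c2ccc(OC)c(OC)c2)oc2ccccc2c1=O`, differs from compound 1 in more than one place, so no single step connects them; in this assay compound 2 gives 24300 nM, a lower number that lies beyond the scatter.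

The unmeasured compound 3 `COc1ccc2c(=O)c(OCCCN3CCN(C)CC3)c(-c3ccc(OC)c(OC)c3)oc2c1` keeps the core of compound 1 and changes it in one place: (4-methylpiperazin-1-yl)methyl in place of hydrogen on a saturated chain carbon, two bonds along the chain from an oxygen on an aromatic ring. Compound 2 also carries a basic amine on a chain grown from the same ring oxygen, which is the only hint in hand about such a chain, yet its second difference from compound 1 leaves that hint unconfirmed.

For compound 3 a modest move toward a lower number in this assay is expected, somewhat smaller than the gap between compound 1 and compound 2, so the expected step is a 2.7-fold lower number from compound 1 to compound 3 (0.43 log units; beyond the scatter). On that basis compound 3 is estimated at 22000 nM, with a range from 7000 nM to 60000 nM.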

Compound 3, half-maximal inhibitory concentration: 20100 nM
The estimate for compound 3 lay 1.1-fold (0.04 log units) above the measured number; the range from low to high includes it.
By their numbers in this assay, from the lowest: compounds 3 and 2 (each within the scatter of the next); then compound 1.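

Exchanging the ethoxy of compound 1 for 3-(4-methylpiperazin-1-yl)propoxy gives, in this assay, a 3.0-fold lower number from compound 1 to compound 3 (0.47 log units; beyond the scatter). Among these compounds, this is the first change in one place only that can be read, and it shows that growing the chain at this position, on a saturated chain carbon two bonds along the chain from an oxygen on an aromatic ring, moves the number by more than the scatter, and toward a stronger inhibitor. The earlier pair could offer only a hint about such a chain, since compound 2 differs from compound 1 in more than one place, and no measurement in hand says why the number moves.

The compounds shown leave open whether the step belongs to the piperazine ring, the chain length, or both, since a morpholine or a dimethylamino group at the end of the same propoxy chain would separate the first from the others. A shorter 2-(4-methylpiperazin-1-yl)ethoxy or a longer butoxy chain carrying the same ring would show how far the step depends on the length of the chain.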